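The source may hold more compounds than are shown below. What is called first, only, known or untested is meant among the compounds shown, and "the series" means these compounds.

Measured compounds in a functional assay on OVCAR-3 cells (Homo sapiens) for inhibition, read by MTT assay, with a stated time of 24 h; on this read-out lower numbers stand for stronger inhibition and higher numbers for weaker inhibition:
Compound 1 `CC1(C)[C@H]2CC[C@]1(C)N(Cc1cn(-c3ccccc3F)nn1)C(=O)C2` gives 300 nM.
Compound 2 `CC1(C)[C@H]2CC[C@]1(C)N(Cc1cn(-c3ccc(F)cc3)nn1)C(=O)C2` gives 200 nM.
Compound 3 `CC1(C)[C@H]2CC[C@]1(C)N(Cc1cn(-c3ccccc3O)nn1)C(=O)C2` gives 90 nM.

Compound 2 stands second highest of the three numbers in this assay. Its nearest neighbour is compound 1, with a 1.5-fold lower number from compound 1 to compound 2 (0.18 log units; within the scatter), and its furthest is compound 3, with a 2.2-fold lower number from compound 2 to compound 3 (0.35 log units; beyond the scatter).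

The unmeasured compound 4 `Cc1ccccc1-n1cc(CN2C(=O)C[C@@H]3CC[C@@]2(C)C3(C)C)nn1` differs from compound 2 in one place: 2-methylphenyl in place of 4-fluorophenyl on an aromatic nitrogen.

For the measured compounds named here, two measured steps bear on this change. Moving a fluoro from the 2-fluorophenyl of compound 1 to the 4-fluorophenyl of compound 2 gave a 1.5-fold lower number from compound 1 to compound 2 (0.18 log units; within the scatter), so the position of a small substituent on that phenyl made no difference beyond the scatter. Exchanging the 4-fluorophenyl for a 2-hydroxyphenyl gave a 2.2-fold lower number from compound 2 to compound 3 (0.35 log units; beyond the scatter), a modest gain that is beyond the scatter. Going by the values given here, the 2-methylphenyl that enters compound 4 carries no hydroxy, so the closer parallel is the first of these steps, and the expectation for this assay is a step of small size, in either direction, most likely within the scatter.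

Compound 4 is therefore expected to give about 220 nM in this assay, with a range from 100 nM to 450 nM. That estimate means a 1.1-fold higher number from compound 2 to compound 4 (0.04 log units; within the scatter), expected to stay within the scatter.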

Compound 4, half-maximal inhibitory concentration: 150 nM
Beside the measured number, compound 4's estimate is 1.5-fold (0.17 log units) above it; the range from low to high includes it.
By their numbers in this assay, from the lowest: compounds 3, 4, 2 and 1 (each within the scatter of the next, the first and the last beyond it).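

In this assay, for the compounds shown here, the earlier compounds carried only fluoro or hydroxy on the phenyl at this aromatic nitrogen, and compound 4 shows that a 2-methylphenyl, whose substituent is carbon alone, can stand there too: exchanging the 4-fluorophenyl for it gives a 1.3-fold lower number from compound 2 to compound 4 (0.12 log units; within the scatter) and so no change that can be told from the scatter. The methyl also cannot be separated from the other two substituents, with a 2.0-fold lower number from compound 1 to compound 4 (0.30 log units; within the scatter) for methyl in place of fluoro and a 1.7-fold higher number from compound 3 to compound 4 (0.22 log units; within the scatter) for methyl in place of hydroxy, even though hydroxy and fluoro themselves differ by a 3.3-fold lower number from compound 1 to compound 3 (0.52 log units; beyond the scatter). A hydroxy is therefore not shown to be required for a number in this range, since compound 4 lacks one and stays within the scatter of compound 3.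

Nothing among the data explains why these substituents behave as they do. Going by these compounds, whether the step stays this small for a larger or charged group on this phenyl, such as an isopropyl, an amine or a carboxylic acid, remains open, as does the outcome of replacing the phenyl altogether.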